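Replacing a Trifluoromethylphenyl Arm with a Sulfamoylphenyl Arm

This account rests on a few compounds, and the source may have more. Where it says the series, first, only, none or still open, it means among the compounds named here.

Of the compounds shown here, three sharing one core have been measured in an assay for binding affinity to dual specificity mitogen-activated protein kinase kinase 4 (Homo sapiens), read by KINOMEscan, tested at 100 nM; on this read-out lower numbers stand for a stronger effect and higher numbers for a weaker effect at the one concentration tested. Compound 1, `CCCS(=O)(=O)Nc1ccc(F)c(C(=O)c2n[nH]c3ncc(-c4cccc(N(C)C)c4)cc23)c1F`, gives 26%. Compound 2, `CCCS(=O)(=O)Nc1ccc(F)c(C(=O)c2n[nH]c3ncc(-c4ccc(OC)cc4Cl)cc23)c1F`, gives 5.3%. Compound 3, `CCCS(=O)(=O)Nc1ccc(F)c(C(=O)c2n[nH]c3ncc(-c4cccc(C(F)(F)F)c4)cc23)c1F`, gives 57%, the highest of the three numbers, meaning the weakest effect among them.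

The step from compound 3 to compound 4, `CCCS(=O)(=O)Nc1ccc(F)c(C(=O)c2n[nH]c3ncc(-c4ccc(S(N)(=O)=O)cc4)cc23)c1F`, changes only the aryl arm: 4-sulfamoylphenyl in place of 3-(trifluoromethyl)phenyl on an aromatic carbon.

Among the measured compounds shown here, two measured steps touch the same position. Moving from compound 1 to compound 3 gave a number 31 percentage points higher from compound 1 to compound 3 (beyond the scatter), and moving from compound 2 to compound 3 gave a number 51.7 percentage points higher from compound 2 to compound 3 (beyond the scatter). In other words, the 3-(trifluoromethyl)phenyl arm of compound 3 sits at the weak end of this small set, and both other aryl arms tried here gave lower numbers. For the measured compounds named here, replacing that arm with 4-sulfamoylphenyl is therefore expected to move the number downward again, by a step larger than the scatter, though the exact size is uncertain because no compound with a sulfamoylphenyl arm has been measured.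

On that basis compound 4 is estimated at 25%, within a range of 5% to 55%, which corresponds to an expected step of a number 32 percentage points lower from compound 3 to compound 4 (beyond the scatter).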

Compound 4, a percentage reported as activity, at one concentration (the size of the read-out at that concentration, not a potency): 0.25%
Estimate against measurement, compound 4: 24.8 percentage points above; measured number below the stated range.
By their numbers in this assay, from the lowest: compounds 4 and 2 (each within the scatter of the next); then compound 1; then compound 3.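

The 4-sulfamoylphenyl arm shows that this position accepts a ring carrying a hydrogen-bond donor and hydrogen-bond acceptors, with a number 56.8 percentage points lower from compound 3 to compound 4 (beyond the scatter) and a number 25.8 percentage points lower from compound 1 to compound 4 (beyond the scatter) in this assay. Against the 2-chloro-4-methoxyphenyl arm there is a number 5.1 percentage points lower from compound 2 to compound 4 (within the scatter) and so no separation, which means that the low end of this set is no longer held by a single arm. The arms of compound 3 and compound 4 hold the same number of heavy atoms, so that count does not separate them, and no measurement at hand accounts for the size of the step.

The change from 3-(trifluoromethyl)phenyl to 4-sulfamoylphenyl alters both the group and its place on the ring, so the compounds shown cannot tell these two apart, whereas a 3-sulfamoylphenyl arm and a 4-(trifluoromethyl)phenyl arm could. From the compounds shown here alone, it also stays open whether the sulfamoyl group itself is needed, or whether a methylsulfonyl group or a carboxylic acid in the same place would give a similar number.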